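The source may report more compounds than this note shows. Statements on the series, on what has been measured and on what is new or still open speak of the compounds shown alone.

For the measured compounds named here, the two compounds measured so far share one core and differ only in methyl groups. Compound 1 `Cc1ccc2c(c1)C1(C(=O)N2C)C(C#N)=C(N)Oc2cc3oc(-c4ccccc4)cc(=O)c3c(O)c21` carries two of them, and in a functional assay on NCI-H1299 cells (Homo sapiens) for antiproliferative activity, read by MTT assay, with a stated time of 48 h (on this read-out lower numbers stand for stronger inhibition and higher numbers for weaker inhibition), compound 1 gives 10200 nM. Compound 2 `N#CC1=C(N)Oc2cc3oc(-c4ccccc4)cc(=O)c3c(O)c2C12C(=O)Nc1ccccc12` carries none. In this assay compound 2 gives > 50000 nM, which is a limit of the assay and not a number. Going by the values given here, compound 2 therefore stands at the upper edge of what the numbers show, at the limit of > 50000 nM in this assay, at which 1 of the 2 values shown sits, and compound 1 is the only one of the pair with a measured value. The unmeasured compound 3 `Cc1ccc2c(c1)C1(C(=O)N2)C(C#N)=C(N)Oc2cc3oc(-c4ccccc4)cc(=O)c3c(O)c21` differs from compound 2 by methyl in place of hydrogen on an aromatic carbon. Among the compounds with values here, no step between measured compounds that differ in one place is available, so the size of this change cannot be read off directly. Compound 3 sits between the two measured compounds, differing from compound 1 by one further methyl. The step is expected to run towards stronger inhibition, an at least 1.6-fold lower number from compound 2 to compound 3 (0.22 log units; that floor lies within the scatter), though it may not exceed the scatter. Compound 3 is expected in this assay to give about 30000 nM, within 10000 nM to 50000 nM.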

Compound 3, half-maximal inhibitory concentration: > 50000 nM
Compound 3: no number, only a limit; the forecaster's own chance of this, stated with the estimate: 40%; at least 1.6-fold (0.22 log units) between middle value and limit.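

Hydrogen in place of methyl on an amide-type nitrogen in a ring gives an at least 4.9-fold higher number from compound 1 to compound 3 (0.69 log units; beyond the scatter) in this assay, the first readable single-place step in this set. It shows that the methyl on this nitrogen matters in the presence of the methyl on the aromatic carbon, a separate contribution that the comparison of compound 1 with compound 2 could not show, as those two differ in two places. The step for methyl in place of hydrogen on an aromatic carbon cannot be read, and only compound 1 has a measured number, with the other compounds at the same limit of the assay: the limit of > 50000 nM in this assay, at which 2 of the 3 values shown sit.

From the compounds shown here alone, it remains open whether the methyl on the aromatic carbon has any effect of its own, and whether the methyl on the nitrogen would have the same effect without it. Going by these compounds, it also remains open whether a longer chain such as ethyl or propyl, or a chain ending in an amine, on the same nitrogen would widen or narrow the difference.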